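The source may report more compounds than this note shows. Statements on the series, on what has been measured and on what is new or still open speak of the compounds shown alone.

Measured so far in a functional assay on K562 cells (Homo sapiens) for antiproliferative activity, with a stated time of 72 h; a higher number here means a weaker inhibitor, a lower number a stronger inhibitor:
- Compound 1 `OC[C@H]1O[C@@H](n2cnc3c(NCc4ccc(Cl)cc4Cl)ncnc32)[C@H](O)[C@@H]1O` gives 106000 nM
- Compound 2 `Cc1cccc(CNc2ncnc3c2ncn3[C@@H]2O[C@H](CO)[C@@H](O)[C@H]2O)c1O` gives 18000 nM

Of these two numbers, compound 2 holds the lower one, 18000 nM, so it is the stronger inhibitor of the pair, though both numbers are large. The next compound to be tested is compound 3 `Cc1ccc(O)c(CNc2ncnc3c2ncn3[C@@H]2O[C@H](CO)[C@@H](O)[C@H]2O)c1`. The change is 2-hydroxy-5-methylphenyl in place of 2-hydroxy-3-methylphenyl on a saturated chain carbon bound to a nitrogen on an aromatic ring. In words, 2-hydroxy-5-methylphenyl takes the place of 2-hydroxy-3-methylphenyl on a saturated chain carbon bound to a nitrogen on an aromatic ring. The two compounds have the same atoms, joined differently.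

Among the measured compounds shown here, only one measured step is available as a guide: a 5.9-fold lower number from compound 1 to compound 2 (0.77 log units; beyond the scatter). That step is modest but beyond the scatter, and it replaced 2,4-dichlorophenyl, a different group altogether. For the measured compounds named here, it says nothing direct about the exchange made here, and no measured pair tests this kind of rearrangement. With so little evidence, no clear direction can be argued, and the expected step is a 1.1-fold higher number from compound 2 to compound 3 (0.05 log units; within the scatter), which means no change beyond the scatter is expected. For compound 3 the estimated value is 20000 nM, with an expected range of 8000 nM to 50000 nM.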

Compound 3, half-maximal inhibitory concentration: 16500 nM
Compound 3: middle estimate off by 1.2-fold (0.08 log units), on the high side, within the range that was stated.
By their numbers in this assay, from the lowest: compounds 3 and 2 (each within the scatter of the next); then compound 1.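

In this assay, moving the methyl group so that 2-hydroxy-5-methylphenyl replaces 2-hydroxy-3-methylphenyl on a saturated chain carbon bound to a nitrogen on an aromatic ring gives a 1.1-fold lower number from compound 2 to compound 3 (0.04 log units; within the scatter) and so does not separate these two arrangements of the same atoms. The step away from 2,4-dichlorophenyl also holds for this second arrangement, with a 6.4-fold lower number from compound 1 to compound 3 (0.81 log units; beyond the scatter) as its size, so the earlier step from compound 1 no longer rests on compound 2 alone, and neither compound shown with a hydroxy and a methyl group goes against this. Nothing available explains these results.

The hydroxyl, the methyl and the absence of the two chlorines all differ together between compound 1 and the other two compounds, so the shown data cannot assign the step to any one of them. As far as these compounds go, a plain 2-hydroxyphenyl group, a 2-methoxy-5-methylphenyl group or an amine in place of the hydroxyl would each change only part of that difference, and the effect of such groups at this place remains open.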